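Cathepsin S series: fluoro on the benzamide of compound 3

The source may report more compounds than this note shows. Statements on the series, on what has been measured and on what is new or still open speak of the compounds shown alone.

Measured compounds:
- compound 1, `CS(=O)(=O)C1CCc2c(c(-c3ccc(C(F)(F)F)c(SCCO)c3)nn2CCCN2CCC(N3CCCC3=O)CC2)C1`: 200 nM
- compound 2, `CS(=O)(=O)N1CCc2c(c(-c3ccc(C(F)(F)F)c(SCCNCc4ccccc4)c3)nn2CCCN2CCC(N3CCCC3=O)CC2)C1`: 700 nM
- compound 3, `CS(=O)(=O)N1CCc2c(c(-c3ccc(C(F)(F)F)c(SCCNC(=O)c4ccccc4)c3)nn2CC(O)CN2CCC(N3CCCC3=O)CC2)C1`: 380 nM

In an assay on isolated protein for inhibition of cathepsin S (Homo sapiens) (a lower number here means a stronger inhibitor, a higher number a weaker inhibitor), compound 3 gives 380 nM, the second highest of the three numbers. Its nearest neighbour is compound 2 with 700 nM, a gap within the scatter; the furthest is compound 1 with 200 nM, also within the scatter. On these three numbers compound 3 is therefore not distinguishable from either of the others, and no order among them can be read.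

For the measured compounds named here, none of the measured pairs differ in one place only, so no single-point step is available to calibrate the change to compound 4, `CS(=O)(=O)N1CCc2c(c(-c3ccc(C(F)(F)F)c(SCCNC(=O)c4ccc(F)cc4)c3)nn2CC(O)CN2CCC(N3CCCC3=O)CC2)C1`. The change is fluoro in place of hydrogen on an aromatic carbon. Nothing in the measured set speaks to an effect of this kind of change, so the expectation rests on the general rule that a single fluorine on a remote aromatic ring seldom moves a number beyond the scatter.

Compound 4 is expected to give about 350 nM in this assay, between 150 nM and 900 nM. The step from compound 3 to compound 4 is estimated at a 1.1-fold lower number from compound 3 to compound 4 (0.04 log units; within the scatter), no direction beyond the scatter.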

Compound 4, half-maximal inhibitory concentration: 360 nM
Estimate against measurement, compound 4: 1.0-fold (0.01 log units) below; measured number inside the range.
By their numbers in this assay, from the lowest: compounds 1, 4, 3 and 2 (each within the scatter of the next, the first and the last beyond it).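

The pair gives the series its first single-point step: phenyl to 4-fluorophenyl on the benzamide reads in this assay as a 1.1-fold lower number from compound 3 to compound 4 (0.02 log units; within the scatter) and so leaves the two amides indistinguishable. At this aromatic carbon, para to a large group, one added fluorine therefore goes with no change beyond the scatter, a statement that holds for this one substituent on the background of compound 3 only. No measurement accompanies the step that could explain this result.

Open, on these data alone, is whether a chloro, methoxy, nitrile or carboxylic acid on this same carbon would move the number beyond the scatter, as the single fluoro does not. Also open, as far as these compounds go, is how the benzamido end compares with the hydroxyl end of compound 1 or the benzylamino end of compound 2; those compounds differ from compound 3 in more than one place, and the steps to them cannot be read.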